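A few compounds are considered here, and "the series" means these few. Any claim that something is new, unique, unknown or untested is made for them only; others in the source may bear on it.

Measured compounds:
compound 1 `CCc1cnc(N2CCC(c3nc(COc4ccc(/C=C5\SC(=S)NC5=O)cc4F)cs3)CC2)nc1` — compound 1 gives "not determined" (no result reported)
compound 2 `CCc1cnc(N2CCC(c3nc(COc4ccc(-n5cnnn5)cc4)cs3)CC2)nc1` — compound 2 gives 87 nM

In a functional assay on cells for agonist activity at Glucose-dependent insulinotropic receptor (Homo sapiens), read by a luciferase reporter, with a stated time of 6 h (on this read-out higher numbers stand for an effect only at larger amounts of compound and lower numbers for an effect already at smaller amounts), compound 1 has no single number, so it cannot be placed against compound 2. Compound 3 `CCc1cnc(N2CCC(c3nc(COc4ccc(/C=C5\CC(=O)NC5=O)cc4F)cs3)CC2)nc1` differs from compound 1 by a group of 8 heavy atoms (5 carbon, 1 nitrogen, 2 oxygen; one five-membered non-aromatic ring with 1 hetero atom) in place of a group of 8 heavy atoms (4 carbon, 1 nitrogen, 1 oxygen, 2 sulfur; one five-membered non-aromatic ring with 2 hetero atoms), on an aromatic carbon. Among the measured compounds shown here, with no value for compound 1, no step size or direction in this assay can be assigned beyond the scatter; the only anchor is compound 2. Compound 3 is estimated at 250 nM, with a range from 40 nM to 2000 nM.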

Compound 3, half-maximal effective concentration: 49 nM
Compound 3: middle estimate off by 5.1-fold (0.71 log units), on the high side, and the stated range covers the measured number.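

Among the compounds shown here, compound 1 has no single number, so no step to compound 3 can be read. The compounds shown leave open how the five-membered non-aromatic ring with 1 hetero atom compares with the one with 2 hetero atoms in this assay. No evidence bears on this result.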